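A few compounds are considered here, and "the series" means these few. Any claim that something is new, unique, unknown or untested is made for them only; others in the source may bear on it.

Compound 3, with the structure `c1ccc(CNCCCCN(C[C@H]2Cc3ccccc3CN2)[C@H]2CCCc3cccnc32)cc1`, was tested in a functional assay on cells for agonist activity at C-X-C chemokine receptor type 4 (Homo sapiens), read by fluorescence and calcium flux, with a stated time of 90 s; a higher number here means that more compound is needed for the effect, a lower number that less compound is needed. In this assay compound 3 gives > 30000 nM, which is a limit of the assay and not a number. The two other compounds measured alongside it sit in the same place. Compound 1, with the structure `c1cncc(CN(CCCCN(C[C@H]2Cc3ccccc3CN2)[C@H]2CCCc3cccnc32)Cc2cccnc2)c1`, gives in this assay > 30000 nM, again a limit rather than a measured number. Compound 2, with the structure `c1ccc2c(c1)CN[C@@H](CN(CCCCN(Cc1ccncc1)Cc1ccncc1)[C@H]1CCCc3cccnc31)C2`, gives in this assay > 30000 nM, also a limit. So compound 3 stands at the limit together with every other compound measured here, and the limit of > 30000 nM in this assay, at which 3 of the 3 values shown sit, describes the whole of what is known so far: no compound among the three has produced a measurable agonist response.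

Compound 4, with the structure `NCc1cccc(CN(C[C@H]2Cc3ccccc3CN2)[C@H]2CCCc3cccnc32)c1`, has not yet been measured in this assay. It differs from compound 3 in one place: 3-(aminomethyl)phenyl in place of 3-(benzylamino)propyl on a saturated chain carbon bound to an amine nitrogen. The three-carbon linker and its benzylamine are gone, and the amine is carried directly on an aromatic ring instead.

With every measured compound sitting at a limit, no step size between measured compounds can be computed. The expected step from compound 3 to compound 4 is a number no higher from compound 3 to compound 4 (the limit leaves the size open), that is, none beyond the scatter, since compound 3 shows only the limit > 30000 nM. Compound 4 is therefore expected to give about 30000 nM, with a range from 10000 nM to 30000 nM, and most likely the assay will again report only a limit.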

Compound 4, half-maximal effective concentration: > 30000 nM
Compound 4: no number, only a limit; the forecaster's own chance of this, stated with the estimate: 85%; the middle value sits exactly at the limit.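

In this assay compound 4 gives > 30000 nM, which is a limit and not a number. Compound 3 also stands at a limit, so no step can be read between compound 3 and compound 4. The compounds shown leave open which structure, if any, gives a measurable agonist response, and all of them stand together: the limit of > 30000 nM in this assay, at which 4 of the 4 values shown sit.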